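Naphthalen-1-yl in place of 3-carboxyphenyl: an expected value

The source may hold more compounds than are shown below. What is called first, only, known or untested is meant among the compounds shown, and "the series" means these compounds.

Compound 1, `COc1cc2nc(N3CCN(S(=O)(=O)c4ccccc4[N+](=O)[O-])CC3)nc(N)c2cc1OC`, gives 35000 nM in a functional assay on PC-3 cells (Homo sapiens) for inhibition; a higher number here means a weaker inhibitor, a lower number a stronger inhibitor.
Compound 2, `COc1ccc(S(=O)(=O)N2CCN(c3nc(N)c4cc(OC)c(OC)cc4n3)CC2)cc1`, gives 39000 nM in this assay.
Compound 3, `COc1cc2nc(N3CCN(S(=O)(=O)c4cccc(C(=O)O)c4)CC3)nc(N)c2cc1OC`, gives 53000 nM in this assay.

Among these three numbers that of compound 3 sits at the upper end, but neither neighbour is separated from it beyond the scatter: a 1.4-fold higher number from compound 2 to compound 3 (0.13 log units; within the scatter) and a 1.5-fold higher number from compound 1 to compound 3 (0.18 log units; within the scatter). All three compounds share one core and differ only in the aryl group on the sulfonyl sulfur.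

Compound 4, `COc1cc2nc(N3CCN(S(=O)(=O)c4cccc5ccccc45)CC3)nc(N)c2cc1OC`, carries the same change of place: naphthalen-1-yl in place of 3-carboxyphenyl on a sulfonyl sulfur. The measured steps that bear on it are the three exchanges of that aryl group, a 1.1-fold higher number from compound 1 to compound 2 (0.05 log units; within the scatter), a 1.5-fold higher number from compound 1 to compound 3 (0.18 log units; within the scatter) and a 1.4-fold higher number from compound 2 to compound 3 (0.13 log units; within the scatter), every one of them within the scatter. Nothing in these numbers points to a swing in either direction for this kind of change, so the step from compound 3 to compound 4 is expected to be a 1.2-fold lower number from compound 3 to compound 4 (0.07 log units; within the scatter), that is, no step beyond the scatter. On that footing compound 4 is estimated to give 45000 nM in this assay, with a range from 18000 nM to 110000 nM.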

Compound 4, half-maximal inhibitory concentration: 14000 nM
Compound 4: the middle estimate sits 3.2-fold (0.51 log units) above what was measured, outside the stated range (below it).
By their numbers in this assay, from the lowest: compound 4; then compounds 1, 2 and 3 (each within the scatter of the next).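

In this assay, the aryl group on the sulfonyl sulfur can move the number beyond the scatter, which the exchanges among compounds 1, 2 and 3 had not shown. Naphthalen-1-yl gives a 3.8-fold lower number from compound 3 to compound 4 (0.58 log units; beyond the scatter) and a 2.8-fold lower number from compound 2 to compound 4 (0.44 log units; beyond the scatter) and also a 2.5-fold lower number from compound 1 to compound 4 (0.40 log units; beyond the scatter) on this measure, all in the same direction and all modest. The step therefore does not depend on leaving 3-carboxyphenyl alone, since it also appears against 4-methoxyphenyl and 2-nitrophenyl, and no evidence on why this change has this effect bears on the result.

The compounds shown do not separate the second aromatic ring of naphthalen-1-yl from the way that group is attached to the sulfonyl sulfur, so the source of the step remains unresolved. A naphthalen-2-yl group, an unsubstituted phenyl group or a biphenyl-4-yl group on the same sulfonyl sulfur would bear on this, and a plain methyl group there would show whether any aromatic ring at all is needed for a number in this range.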